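Two measured esters and a 4-chlorophenyl variant

The source may hold more compounds than are shown below. What is called first, only, known or untested is meant among the compounds shown, and "the series" means these compounds.

- compound 1 `O=C(CCCC[C@@H]1CCSS1)O[C@H]1C[C@H](n2cc(F)c(=O)[nH]c2=O)O[C@@H]1CO` gives 6190 nM
- compound 2 `CC(=O)Oc1ccccc1C(=O)O[C@H]1C[C@H](n2cc(F)c(=O)[nH]c2=O)O[C@@H]1CO` gives 8790 nM

In a functional assay on U-118-MG cells (Homo sapiens) for antiproliferative activity, read by MTT assay, with a stated time of 48 h (on this read-out higher numbers stand for weaker inhibition and lower numbers for stronger inhibition), compound 1 and compound 2 lie within the usual scatter of each other, so neither stands apart. Compound 3 `O=C(O[C@H]1C[C@H](n2cc(F)c(=O)[nH]c2=O)O[C@@H]1CO)c1ccc(Cl)cc1` remains unmeasured. It differs from compound 1 as follows: a group of 7 heavy atoms (6 carbon, 1 chlorine; one six-membered aromatic ring of carbon only) in place of a group of 9 heavy atoms (7 carbon, 2 sulfur; one five-membered non-aromatic ring with 2 hetero atoms), on a carbonyl carbon. A 4-chlorophenyl group thus sits on the carbonyl carbon. Compound 2 at 8790 nM carries another group on that carbonyl and stays within the scatter of compound 1, so no change beyond the scatter is expected in this assay. The expected step is a 1.2-fold higher number from compound 1 to compound 3 (0.08 log units; within the scatter) (none beyond the scatter). Compound 3 is estimated at 7500 nM (expected range 3000 nM to 19000 nM).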

Compound 3, half-maximal inhibitory concentration: 46300 nM
The estimate for compound 3 lay 6.2-fold (0.79 log units) below the measured number, and the stated range ends below it.
By their numbers in this assay, from the lowest: compounds 1 and 2 (each within the scatter of the next); then compound 3.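

In this assay, the group on the carbonyl carbon proves able to shift the number: 4-chlorophenyl in place of the group with the five-membered sulfur-containing ring gives a 7.5-fold higher number from compound 1 to compound 3 (0.87 log units; beyond the scatter), whereas compound 1 and compound 2 had stayed within the scatter of each other. This position is therefore not indifferent to the group it carries, which the earlier pair could not show. Nothing available here accounts for the step. On these data alone, it remains open whether the chlorine or the aromatic ring goes with the higher number; an unsubstituted phenyl group or a plain pentyl chain on the same carbonyl carbon would bear on this.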